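The source may report more compounds than this note shows. Statements on the series, on what has been measured and on what is new or still open speak of the compounds shown alone.

Compound 1 `COc1ccc(OC)c(/C=C/C(=O)/C=C(O)/C=C/c2cc(OC)ccc2OC)c1`: > 50000 nM
Compound 2 `COc1cccc(/C=C/C(=O)C(=Cc2cc(OC)c(OC)c(OC)c2)C(=O)/C=C/c2cccc(OC)c2OC)c1OC`: 840 nM

In a functional assay on MCF7 cells (Homo sapiens) for antiproliferative activity, read by sulforhodamine B assay, with a stated time of 48 h (a lower number here means a stronger inhibitor, a higher number a weaker inhibitor), compound 1 gives > 50000 nM, which is a limit and not a number. For the measured compounds named here, in the same this assay, compound 2 gives 840 nM, the only true number so far. Compound 3 `COc1cccc(/C=C/C(=O)C(=Cc2ccc(OC)c(OC)c2OC)C(=O)/C=C/c2cccc(OC)c2OC)c1OC` has the same atoms as compound 2, joined differently: 2,3,4-trimethoxyphenyl in place of 3,4,5-trimethoxyphenyl on a double-bonded chain carbon bound to a double-bonded chain carbon. Going by the values given here, no measured step shows what such a change does, so only a modest weakening in this assay is expected, and this direction is a tentative call. The expected change is a 1.8-fold higher number from compound 2 to compound 3 (0.25 log units; within the scatter). Compound 3 is estimated at 1500 nM, with an expected range of 500 nM to 6000 nM.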

Compound 3, half-maximal inhibitory concentration: 380 nM
Compound 3: middle estimate off by 3.9-fold (0.60 log units), on the high side, outside the stated range (below it).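

In this assay, for the compounds shown here, the swap of 3,4,5-trimethoxyphenyl for 2,3,4-trimethoxyphenyl on a double-bonded chain carbon bound to a double-bonded chain carbon gives a 2.2-fold lower number from compound 2 to compound 3 (0.34 log units; beyond the scatter) and this is the first measured step. It shows that with the same atoms, rearranging the methoxy groups on this ring is enough to shift the number modestly, in the stronger direction. Nothing measured here accounts for that shift.

Still open, on these data alone, is what a ring carrying an amine or a carboxylic acid in place of these methoxy groups would do at this place. One step also cannot show whether the same swap would give a similar shift on another core.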